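A nitro group on the amide-side phenyl of compound 1

The source may report more compounds than this note shows. Statements on the series, on what has been measured and on what is new or still open speak of the compounds shown alone.

Measured compounds:
compound 1, `O=C(Nc1cc(-c2ccccc2)nn1-c1ccccc1Br)c1ccccc1` — 2600 nM
compound 2, `O=C(Nc1cc(-c2ccccc2)nn1-c1cccc(Br)c1)c1ccccc1` — a limit, > 10000 nM

For the measured compounds named here, compound 1 `O=C(Nc1cc(-c2ccccc2)nn1-c1ccccc1Br)c1ccccc1` gives 2600 nM in an assay on HEK293 cells for displacement of a labelled ligand from metabotropic glutamate receptor 5 (Rattus norvegicus) (on this read-out higher numbers stand for weaker inhibition and lower numbers for stronger inhibition), the only number reported for this set. Compound 2 `O=C(Nc1cc(-c2ccccc2)nn1-c1cccc(Br)c1)c1ccccc1` reaches only a limit of > 10000 nM in this assay. The step of an at least 3.8-fold higher number from compound 1 to compound 2 (0.58 log units; beyond the scatter) changes the aryl on the ring nitrogen and is at least modest, resting on (the limit of > 10000 nM in this assay, at which 1 of the 2 values shown sits).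

Compound 3 `O=C(Nc1cc(-c2ccccc2)nn1-c1ccccc1Br)c1cccc([N+](=O)[O-])c1` differs from compound 1 on the other side of the molecule: nitro in place of hydrogen on an aromatic carbon, so the phenyl on the carbonyl side becomes 3-nitrophenyl. Going by the values given here, no measured step touches this phenyl; the only step, from compound 1 to compound 2, concerns the aryl on the nitrogen and gives no guide to the present change. For compound 3 the step of no change at the digits printed from compound 1 to compound 3 (within the scatter) is therefore expected to stay within the scatter. The estimate for compound 3 is 2600 nM, expected to lie between 800 nM and 9000 nM.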

Compound 3, inhibition constant: 230 nM
Compound 3: the middle estimate sits 11-fold (1.05 log units) above what was measured; measured number below the stated range.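

In this assay, 3-nitrophenyl in place of phenyl gives an 11-fold lower number from compound 1 to compound 3 (1.05 log units; beyond the scatter), so the read-out responds to a change on the carbonyl side of the molecule and not only to the aryl on the ring nitrogen. For the compounds shown here, this step joins two measured numbers, and it shows that the phenyl on the carbonyl side, which the earlier compounds left unchanged, can carry a nitro group with stronger inhibition as the result. Nothing shown here accounts for why this change has such an effect.

On these data alone, whether the gain belongs to the nitro group itself, or would also appear with an amine, a nitrile or a methoxy group in the same place, stays open. Also open, as far as these compounds go, is whether the nitro group would give a similar gain with 3-bromophenyl on the ring nitrogen, as in compound 2.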